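Swapping the piperazine cap: oxadiazole to carbamate

A few compounds are considered here, and "the series" means these few. Any claim that something is new, unique, unknown or untested is made for them only; others in the source may bear on it.

Three amides sharing one core have been measured in a functional assay on MIA PaCa-2 cells (Homo sapiens) for inhibition, read by MTT assay, with a stated time of 3 days; a lower number here means a stronger inhibitor, a higher number a weaker inhibitor. Compound 1 `CCN(CC)S(=O)(=O)c1ccc(S(=O)(=O)N2CCC[C@@H](C(=O)NC3CN(C(=O)OC(C)(C)C)C3)C2)cc1` gives 100 nM in this assay, compound 2 `CCN(CC)S(=O)(=O)c1ccc(S(=O)(=O)N2CCC[C@@H](C(=O)N(C)C(C)C)C2)cc1` gives 1400 nM, and compound 3 `CCN(CC)S(=O)(=O)c1ccc(S(=O)(=O)N2CCC[C@@H](C(=O)N3CCN(c4nc(C)no4)CC3)C2)cc1` gives 200 nM. The steps are a 14-fold higher number from compound 1 to compound 2 (1.15 log units; beyond the scatter) and a 2.0-fold higher number from compound 1 to compound 3 (0.30 log units; within the scatter), with a 7.0-fold lower number from compound 2 to compound 3 (0.85 log units; beyond the scatter) linking the two amide variants. Compound 3 thus sits second of the three numbers, within the scatter of compound 1 and well apart from compound 2.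

Compound 4 `CCN(CC)S(=O)(=O)c1ccc(S(=O)(=O)N2CCC[C@@H](C(=O)N3CCN(C(=O)OC(C)(C)C)CC3)C2)cc1` keeps the piperazine amide of compound 3 and changes only its far nitrogen: tert-butoxycarbonyl in place of 3-methyl-1,2,4-oxadiazol-5-yl on an amine nitrogen in a ring. Within the data shown here, no measured step touches this position, so the bearing of the earlier steps is indirect. Compound 1, which also carries a tert-butoxycarbonyl on a ring nitrogen, gives 100 nM, and the gap between compounds 1 and 3 is small. The author therefore expects compound 4 to move little, a 1.3-fold lower number from compound 3 to compound 4 (0.12 log units; within the scatter), and estimates 150 nM for compound 4, between 50 nM and 450 nM.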

Compound 4, half-maximal inhibitory concentration: 10 nM
Compound 4: the middle estimate sits 15-fold (1.18 log units) above what was measured, outside the stated range (below it).
By their numbers in this assay, from the lowest: compound 4; then compounds 1 and 3 (each within the scatter of the next); then compound 2.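

In this assay the far nitrogen of the piperazine amide proves to be a sensitive position, with a 20-fold lower number from compound 3 to compound 4 (1.30 log units; beyond the scatter) when tert-butoxycarbonyl replaces 3-methyl-1,2,4-oxadiazol-5-yl. Among these compounds, none of the earlier steps touched this nitrogen, and the closeness of compound 1 and compound 3 gave no sign that a single change of cap could move the number this far. The data shown offer no measurement that accounts for the size of this step.

The compounds shown leave open whether the step belongs to the carbonyl or to the tert-butyl part of the tert-butoxycarbonyl group. A methoxycarbonyl, a pivaloyl or a plain tert-butyl group on the same nitrogen would separate these two parts.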